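A few compounds are considered here, and "the series" means these few. Any claim that something is new, unique, unknown or untested is made for them only; others in the source may bear on it.

Measured so far:
- compound 1, `Cc1c(C)c2ccc(OCCCCCCN(C)Cc3ccccc3)cc2oc1=O`: 1700 nM
- compound 2, `CN(C)Cc1cccc(COc2ccc3ccc(=O)oc3c2)c1`: 3200 nM

In an assay for inhibition of Amine oxidase [flavin-containing] B (Rattus norvegicus), read by spectrophotometry (on this read-out lower numbers stand for stronger inhibition and higher numbers for weaker inhibition), compound 2 gives the higher of the two numbers measured; compound 1 gives a number lower than that of compound 2, but this gap lies within the scatter, so the two cannot be ordered. Among the measured compounds shown here, no pair of measured compounds differing in a single place has been recorded, so the series offers no measured step to lean on.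

Compound 3, `CN(Cc1cccc(C#N)c1)Cc1cccc(COc2ccc3ccc(=O)oc3c2)c1`, carries the change 3-cyanophenyl in place of hydrogen on a saturated chain carbon bound to an amine nitrogen relative to compound 2. With nothing comparable measured, only a small step is expected from compound 2 to compound 3 in this assay, more likely toward lower numbers than higher, and possibly no more than the scatter. Compound 3 is therefore estimated at 2000 nM, with a range from 500 nM to 8000 nM, corresponding to an expected step of a 1.6-fold lower number from compound 2 to compound 3 (0.20 log units; within the scatter).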

Compound 3, half-maximal inhibitory concentration: 3700 nM
Beside the measured number, compound 3's estimate is 1.9-fold (0.27 log units) below it; measured number inside the range.
By their numbers in this assay, from the lowest: compounds 1, 2 and 3 (each within the scatter of the next, the first and the last beyond it).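

In this assay, among the compounds shown here, the step of a 1.2-fold higher number from compound 2 to compound 3 (0.06 log units; within the scatter) is the first measured single-place change, and it puts a number on methyl to 3-cyanobenzyl at this position. The 3-cyanophenyl group brings 8 heavy atoms onto a saturated chain carbon bound to an amine nitrogen, yet the two values cannot be told apart, so this added bulk leaves the read-out unmoved in this one pair. No measurement at hand bears on why this is so.

The compounds shown do not separate the contribution of the aromatic ring from that of the nitrile, which a plain benzyl group at the same place would address. As far as these compounds go, how a longer chain between the amine nitrogen and the ring, or a carboxylic acid in place of the nitrile, would read also remains open.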